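Taking Away a Hydroxy Group: Three Measured, One Expected

This account rests on a few compounds, and the source may have more. Where it says the series, first, only, none or still open, it means among the compounds named here.

The measured compounds in a functional assay on MCF7 cells (Homo sapiens) for cytotoxicity, read by MTT assay, with stated times of 6 h and 48 h; a lower number here means a stronger inhibitor, a higher number a weaker inhibitor:
compound 1, `Cn1c(/C=C/C(=O)c2ccccc2O)cc(Br)c1Br`, gives 2510 nM;
compound 2, `Cn1c(/C=C/C(=O)c2ccc(O)cc2O)cc(Br)c1Br`, gives 1610 nM;
compound 3, `O=C(/C=C/c1cc(Br)c(Br)[nH]1)c1ccccc1O`, gives 1490 nM.

Compound 2 and compound 1 differ by one change, (hydrogen in place of hydroxy on an aromatic carbon), and that step was a 1.6-fold higher number from compound 2 to compound 1 (0.19 log units; within the scatter). Compound 1 and compound 3 also differ in one place, with a step of a 1.7-fold lower number from compound 1 to compound 3 (0.23 log units; within the scatter). Compound 2 and compound 3 differ in more than one place, and the difference between their two cores is not broken down here.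

Compound 4, `O=C(/C=C/c1cc(Br)c(Br)[nH]1)c1ccccc1`, is not yet measured. It comes from compound 3 by hydrogen in place of hydroxy on an aromatic carbon. Among the measured compounds shown here, this is the same kind of change as the one between compound 2 and compound 1, but not the same: there the leaving hydroxy sat meta to a hydroxy group and para to a large group, here it sits ortho to a large group. Because that earlier step was a 1.6-fold higher number from compound 2 to compound 1 (0.19 log units; within the scatter), the step now expected in this assay is a 1.8-fold higher number from compound 3 to compound 4 (0.26 log units; within the scatter), kept a little larger to allow for the different place. Compound 4 is therefore estimated at 2700 nM, most likely between 1300 nM and 6500 nM.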

Compound 4, half-maximal inhibitory concentration: 12200 nM
For compound 4 the middle estimate is 4.5-fold (0.65 log units) below the measured one; measured number outside the range, above it.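

In this assay, taking the hydroxy group away from compound 3 has a large effect, with an 8.2-fold higher number from compound 3 to compound 4 (0.91 log units; beyond the scatter). The same change therefore does not carry over at the same size from one core to the other: the same change on two cores in this assay, a 1.6-fold higher number (0.19 log units; within the scatter) from compound 2 to compound 1 and an 8.2-fold higher number (0.91 log units; beyond the scatter) from compound 3 to compound 4, 5.3-fold (0.72 log units) apart, beyond the scatter of two such steps. Among the compounds shown here, these two steps do not show why the sizes differ, as the leaving hydroxy in compound 3 sits ortho to a large group, the one in compound 2 sits elsewhere, and the cores also differ.

From the compounds shown here alone, it remains open whether a methoxy group or an amine in that ortho place would behave like the hydroxy. Going by these compounds, the same removal from compound 1, which would keep the methyl on the ring nitrogen, also remains open.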